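Halogen swap on the amide aryl: cytotoxicity working notes

A few compounds are considered here, and "the series" means these few. Any claim that something is new, unique, unknown or untested is made for them only; others in the source may bear on it.

Measured so far:
compound 1 `O=C(CSc1snnc1-c1ccc(Br)cc1Br)Nc1ccccn1`: 42400 nM
compound 2 `O=C(CSc1snnc1-c1ccc(Br)cc1Br)Nc1ccccc1F`: >= 27800 nM

In an ADME assay on MT4 cells (Homo sapiens) for cytotoxicity, read by MTT assay, with a stated time of 5 days (a lower number here means that less compound is tolerated, a higher number that more compound is tolerated), compound 1 gives 42400 nM. Compound 2 returns only a limit in this assay, >= 27800 nM. The step that the limit leaves unreadable from compound 1 to compound 2 is therefore not readable, as the limit of >= 27800 nM in this assay, at which 1 of the 2 values shown sits, shows. Compound 2 stands at that limit and nowhere more precise.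

Compound 3 `O=C(CSc1snnc1-c1ccc(Br)cc1Br)Nc1ccccc1Br` differs from compound 2 by bromo in place of fluoro on an aromatic carbon. For the measured compounds named here, no measured step bears on this change; only the limit of compound 2 is available. The step expected here is a step that the limit leaves unreadable from compound 2 to compound 3 and it lies within the scatter. Compound 3 is estimated at 30000 nM, with an expected range from 12000 nM to 70000 nM.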

Compound 3, half-maximal cytotoxic concentration: > 221000 nM
Compound 3: no number, only a limit; the forecaster's own chance of this, stated with the estimate: 50%; at least 7.3-fold (0.86 log units) between middle value and limit.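

In this assay compound 3 gives > 221000 nM as a limit, not a number. For the compounds shown here, replacing pyridin-2-yl with 2-bromophenyl on the amide nitrogen gives an at least 5.2-fold higher number from compound 1 to compound 3 (0.71 log units; beyond the scatter) and is the first readable step, beyond the scatter. The steps involving compound 2 cannot be read, and with limits on both compound 2 and compound 3, the order of fluoro and bromo cannot be told.

Still open, from the compounds shown here alone, is how far compound 3 lies past its limit. Also open, going by these compounds, is what a chloro or a methoxy on the same aromatic carbon would give.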